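The source may report more compounds than this note shows. Statements on the series, on what has been measured and on what is new or still open speak of the compounds shown alone.

Compound 1 `O=c1[nH]c(=O)n(CCC(CO)CO)cc1-c1ccco1` is the starting point. In a functional assay on MCF7 cells (Homo sapiens) for antiproliferative activity, read by MTT assay, with a stated time of 72 h (a higher number here means a weaker inhibitor, a lower number a stronger inhibitor), compound 1 reaches only a limit of the assay, < 10 nM, so its true potency is not pinned down. A second measured compound, compound 2 `CC(=O)OCC(CCn1cc(C#CC(C)(C)C)c(=O)n(C(=O)c2ccccc2)c1=O)COC(C)=O`, differs from compound 1 in several places at once; in this assay compound 2 gives 67100 nM. Among the compounds with values here, the two values show a very wide spread, but no single-point step between them is defined. The line the limit of < 10 nM in this assay, at which 1 of the 2 values shown sits, marks where compound 1 sits. Compound 3 `O=c1[nH]c(=O)n(CCC(CO)CO)cc1C#CC1CC1` follows from compound 1 by one change, (2-cyclopropylethynyl in place of furan-2-yl on an aromatic carbon), that is, 2-cyclopropylethynyl in place of furan-2-yl on an aromatic carbon. Within the data shown here, no measured pair isolates such a swap. With the starting value known only as a limit, the expected step is a loss beyond the scatter, an at least 5.0-fold higher number from compound 1 to compound 3 (0.69 log units; beyond the scatter). Compound 3 is therefore estimated at 50 nM, within a range of 5 nM to 500 nM.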

Compound 3, half-maximal inhibitory concentration: > 100000 nM
Compound 3: no number, only a limit; the forecaster's own chance of this, stated with the estimate: 25%; at least 2000-fold (3.30 log units) between middle value and limit.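

In this assay, putting 2-cyclopropylethynyl in place of furan-2-yl on this aromatic carbon gives an at least 10000-fold higher number from compound 1 to compound 3 (4.00 log units; beyond the scatter). From the compounds shown here alone, both ends of this step are limits of the assay and not numbers, so its printed size is a minimum and its true size remains unknown. Unlike the earlier comparison, which involved changes in several places at once, this pair isolates one position and shows that activity here does not follow the heavy-atom count alone, since both groups have the same count and the rest of the structure is shared.

The compounds shown do not separate the contributions of the triple bond, the three-membered ring and the loss of the furan ring. Going by these compounds, whether a thiophen-2-yl group, a phenyl group or an amine at this position would retain the activity of compound 1 also remains open.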